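Vinyl to ethyl on the core of compound 1

The source may hold more compounds than are shown below. What is called first, only, known or untested is meant among the compounds shown, and "the series" means these compounds.

Going by the values given here, in a functional assay on HL-60 cells (Homo sapiens) for antiproliferative activity, read by MTT assay (on this read-out higher numbers stand for weaker inhibition and lower numbers for stronger inhibition), compound 1 `C=C[C@@H]1O[C@H](COCc2ccccc2)[C@@H](OCc2ccccc2)[C@H](OCc2ccccc2)[C@H]1O` gives 11800 nM as the only number. Compound 2 `O[C@@H]1[C@@H](OCc2ccccc2)[C@H](OCc2ccccc2)[C@@H](COCc2ccccc2)O[C@]12CCCO2` is reported as "not active" (no number reported) and carries no number. Compound 3 `C=C[C@H]1O[C@H](COCc2ccccc2)[C@@H](OCc2ccccc2)[C@H](OCc2ccccc2)[C@H]1O` is likewise reported as "not active" (no number reported) and carries no number. One pair stands out: the fact that compounds 1 and 3 differ only in the configuration as drawn is all that separates them, yet compound 1 gives a number and compound 3 does not.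

The next compound is compound 4 `CC[C@@H]1O[C@H](COCc2ccccc2)[C@@H](OCc2ccccc2)[C@H](OCc2ccccc2)[C@H]1O` with ethyl in place of vinyl on a saturated ring carbon and the rest of the core of compound 1 unchanged. Among the compounds with values here, no measured step in this assay gives a size for this kind of change, so the working expectation is no shift beyond the scatter, in neither direction. The sole anchor for that expectation is compound 1 at 11800 nM and nothing else in the series sets a scale. The expected step of a 1.2-fold higher number from compound 1 to compound 4 (0.07 log units; within the scatter) stays within the scatter. Compound 2 and compound 3 gave no number, so a result without a number also remains possible for the new compound. Compound 4 is expected at 14000 nM (estimated range 6000 nM to 35000 nM).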

Compound 4, half-maximal inhibitory concentration: 8200 nM
Compound 4: the middle estimate sits 1.7-fold (0.23 log units) above what was measured, and the stated range covers the measured number.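

In this assay, ethyl in place of vinyl gives a 1.4-fold lower number from compound 1 to compound 4 (0.16 log units; within the scatter), the first step measured at this position on a saturated ring carbon next to the ring oxygen. With the configuration of compound 1, a numerical result therefore does not depend on the double bond of vinyl, and ethyl and vinyl cannot be told apart on this read-out. Going by these compounds alone, this swap does not separate a number from no number, so the sharper contrast remains the one between compound 1 and compound 3, which gives no number: the fact that compounds 1 and 3 differ only in the configuration as drawn.

On these data alone, whether ethyl in the configuration of compound 3 gives a number remains open, so the two-compound contrast cannot yet be extended beyond vinyl. Also open, as far as these compounds go, is how far this position tolerates other groups, such as a longer chain like propyl, an amine or a carboxylic acid, and whether any of them would move the number beyond the scatter in either direction.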